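Nitro in place of hydrogen on an aromatic carbon

A few compounds are considered here, and "the series" means these few. Any claim that something is new, unique, unknown or untested is made for them only; others in the source may bear on it.

For the measured compounds named here, in a functional assay on DU-145 cells (Homo sapiens) for antiproliferative activity, read by MTT assay, with a stated time of 72 h (a higher number here means a weaker inhibitor, a lower number a stronger inhibitor), two compounds have numbers so far. Compound 1 `O=C1OCC[C@@H]1NC(=S)SCCOc1ccc([N+](=O)[O-])cc1` gives 31000 nM, and compound 2 `O=C1OCC[C@@H]1NC(=S)SCCOc1ccccc1` gives 63800 nM, the higher of the two numbers and so the weaker inhibitor of this pair. Compound 3 `O=C1OCC[C@@H]1NC(=S)SCCOc1ccccc1[N+](=O)[O-]` has not yet been measured. It differs from compound 2 by nitro in place of hydrogen on an aromatic carbon, ortho to a large group.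

Going by the values given here, only one measured step bears on this change: a 2.1-fold higher number from compound 1 to compound 2 (0.31 log units; beyond the scatter). It is modest and lies beyond the scatter, and it exchanges the same two substituents in the opposite sense. Among the compounds with values here, the nitro of compound 3 does not stand where the nitro of compound 1 stands, however, and no measured compound carries it in the new place, so that step is only a loose guide. The step expected is a 1.5-fold lower number from compound 2 to compound 3 (0.18 log units; within the scatter), a modest one towards a lower number in this assay, though the direction is not secure. For compound 3 the estimated value is 42000 nM, with an expected range of 20000 nM to 80000 nM.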

Compound 3, half-maximal inhibitory concentration: 33400 nM
Estimate against measurement, compound 3: 1.3-fold (0.10 log units) above, and the stated range covers the measured number.
By their numbers in this assay, from the lowest: compounds 1, 3 and 2 (each within the scatter of the next, the first and the last beyond it).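

In this assay, placing nitro on an aromatic carbon ortho to a large group gives a 1.9-fold lower number from compound 2 to compound 3 (0.28 log units; within the scatter), so at this place the change stays within the scatter, whereas the step involving the nitro of compound 1 is a 2.1-fold higher number from compound 1 to compound 2 (0.31 log units; beyond the scatter) and lies just beyond it. For the compounds shown here, compound 1 at 31000 nM and compound 3 at 33400 nM fall within the scatter of each other, so the two nitro places cannot be told apart by these numbers, and the series so far gives no sign that the place of the nitro on the ring matters. Nothing at hand accounts for these numbers.

The compounds shown leave open whether a different group at this same place ortho to a large group, such as an amine, a carboxylic acid or a methoxy, would separate from compound 2 beyond the scatter. They also leave open whether the small differences among compounds 1, 2 and 3 would persist with a longer chain between the sulfur and the ether oxygen.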